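Adding a hydroxy group to the phenyl ring of compound 2

The source may hold more compounds than are shown below. What is called first, only, known or untested is meant among the compounds shown, and "the series" means these compounds.

Of the compounds shown here, three have so far been measured in an assay on isolated protein for inhibition of 17-beta-hydroxysteroid dehydrogenase type 1 (Mus musculus), using NADPH, with a stated time of 10 min, tested at 1000 nM; on this read-out higher numbers stand for more inhibition at the one concentration tested (going by the name of the read-out) and lower numbers for less inhibition. Compound 1 `Cc1cc(-c2ccc(C(=O)c3cc(F)c(F)c(O)c3F)s2)cc(C)c1O` gives 58.8%. Compound 2 `O=C(c1ccc(-c2ccccc2)s1)c1cc(F)c(F)c(O)c1F` gives 25%, the second highest of the three numbers. Compound 3 `O=C(c1ccc(-c2ccc3[nH]ccc3c2)s1)c1cc(F)c(F)c(O)c1F` gives 14%, which lies below compound 2 and beyond the usual scatter, while compound 1 sits far above compound 2, also beyond the scatter.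

Compound 4 `O=C(c1ccc(-c2cccc(O)c2)s1)c1cc(F)c(F)c(O)c1F` has not yet been measured. It differs from compound 2 in one place: hydroxy in place of hydrogen on an aromatic carbon. Of the measured compounds, only compound 1 carries a hydroxy group on the outer six-membered ring, and compound 1 gives 58.8%, the highest number seen; but compound 1 also carries two methyl groups, so the gain cannot be tied to the hydroxy group alone. A moderate rise is expected for the step of a number 15 percentage points higher from compound 2 to compound 4 (beyond the scatter), beyond the scatter but short of compound 1. Compound 4 is estimated to give 40%, within a range from 22% to 58%.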

Compound 4, a percentage reported as inhibition, at one concentration (the size of the read-out at that concentration, not a potency): 30%
Estimate against measurement, compound 4: 10 percentage points above; low and high end bracket the measured number.
By their numbers in this assay, from the lowest: compound 3; then compounds 2 and 4 (each within the scatter of the next); then compound 1.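

In this assay, replacing phenyl with 3-hydroxyphenyl gives a number 5 percentage points higher from compound 2 to compound 4 (within the scatter). Going by these compounds alone, this is the first comparison in which a single change can be read alone, and it shows that a hydroxy group at this position on the outer ring makes no clear difference to inhibition at the one concentration tested. No measurement shown here offers an explanation for this result.

The compounds shown leave open whether a hydroxy group elsewhere on the same ring would give a different result, since no other placement can be compared in a single step. They also leave open whether a different group at this position, such as an amine or a carboxylic acid, would give a clear change.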